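The compounds below may be only part of what the source reports. "The series", "measured", "known", "first", "only" and "open" are said of these compounds alone.

In a functional assay on NPC-TW01 cells (Homo sapiens) for inhibition, read by MTT assay, with a stated time of 72 h (on this read-out lower numbers stand for stronger inhibition of growth and higher numbers for weaker inhibition of growth), compound 1 `COC(=O)c1nc(C)n(-c2ccccc2C(F)(F)F)n1` reaches only a limit of the assay, > 100000 nM, so no number is known for it. Compound 2 `CCc1nc(C(=O)OC)nn1-c1ccc(F)cc1` gives 15800 nM in this assay. Going by the values given here, compound 2 therefore holds the only number among the values shown, while the one other value is a limit, (the limit of > 100000 nM in this assay, at which 1 of the 2 values shown sits).

Compound 3 `COC(=O)c1nc(-c2ccc[nH]2)n(-c2ccc(F)cc2)n1` has not yet been measured in this assay. It differs from compound 2 in one place: 1H-pyrrol-2-yl in place of ethyl on an aromatic carbon. Among the compounds with values here, no step between two measured compounds is available to show how a change of this kind has behaved in this assay, so the expectation can rest only on what compound 2 shows and on the nature of the replacement. A step of modest size in this assay is expected, one that could go in either direction and that need not reach far beyond the usual scatter.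

On that basis compound 3 is estimated at 12000 nM, with a range from 2500 nM to 60000 nM. The expected step is a 1.3-fold lower number from compound 2 to compound 3 (0.12 log units; within the scatter).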

Compound 3, concentration for 50% growth inhibition: 9580 nM
Beside the measured number, compound 3's estimate is 1.3-fold (0.10 log units) above it; the measured number falls inside the stated range.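

In this assay, 1H-pyrrol-2-yl in place of ethyl on this aromatic carbon gives a 1.6-fold lower number from compound 2 to compound 3 (0.22 log units; within the scatter). Going by these compounds alone, this is the first step between compounds that differ in one place, and it shows that a five-membered aromatic ring with a hydrogen-bond donor can stand between the two ring nitrogen atoms without a shift that can be told apart from the scatter, so the number stays where ethyl left it even though the entering group is the larger one. Nothing measured in the data bears on this result.

What the compounds shown leave open is whether any group at this place can move the number beyond the scatter, such as an amine, a longer chain or a phenyl ring, and whether a carboxylic acid in place of the methoxycarbonyl group would do so. They also cannot separate the ring of 1H-pyrrol-2-yl from its hydrogen-bond donor, which would take a furan-2-yl group at the same place.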